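Acyl thiourea series on a nitrobenzothiazole core: morpholine carboxamide

The compounds below may be only part of what the source reports. "The series", "measured", "known", "first", "only" and "open" are said of these compounds alone.

Measured so far, cytotoxicity toward MCF7 cells:
- compound 1 `CCCCC(=O)NC(=S)Nc1nc2cc([N+](=O)[O-])ccc2s1`: > 100000 nM
- compound 2 `O=C(NC(=S)Nc1nc2cc([N+](=O)[O-])ccc2s1)c1ccc([N+](=O)[O-])cc1`: 35200 nM
- compound 3 `O=C(NC(=S)Nc1nc2cc([N+](=O)[O-])ccc2s1)c1cccs1`: 35900 nM

In a functional assay on MCF7 cells (Homo sapiens) for cytotoxicity, read by MTT assay, with a stated time of 24 h (on this read-out lower numbers stand for stronger inhibition and higher numbers for weaker inhibition), compound 1 gives only a limit, (the limit of > 100000 nM in this assay, at which 1 of the 3 values shown sits). Compound 3 holds the highest of the two real numbers, with compound 2 nearest: a 1.0-fold higher number from compound 2 to compound 3 (0.01 log units; within the scatter). Both aromatic groups in place of butyl on the carbonyl carbon gave a lower number, an at least 2.8-fold lower number from compound 1 to compound 2 (0.45 log units; beyond the scatter) and an at least 2.7-fold lower number from compound 1 to compound 3 (0.44 log units; beyond the scatter).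

Compound 4 `O=C(NC(=S)Nc1nc2cc([N+](=O)[O-])ccc2s1)N1CCOCC1` differs from compound 3 in one place: morpholin-4-yl in place of thiophen-2-yl on a carbonyl carbon. The steps from compound 1 bear on this, since the entering group is a six-membered non-aromatic ring rather than an aromatic one, and the butyl compound 1 sat at the limit. A higher number, toward that limit, is therefore expected for compound 4: a 1.8-fold higher number from compound 3 to compound 4 (0.26 log units; within the scatter). The estimate for compound 4 in this assay is 65000 nM, with a range from 25000 nM to 150000 nM, and a real chance that only a limit is reported.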

Compound 4, half-maximal inhibitory concentration: 31000 nM
Compound 4: the middle estimate sits 2.1-fold (0.32 log units) above what was measured, within the range that was stated.
By their numbers in this assay, from the lowest: compounds 4, 2 and 3 (each within the scatter of the next). At a limit, above all of these: compound 1.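

In this assay, morpholin-4-yl on the carbonyl carbon sits level with both aromatic groups: a 1.2-fold lower number from compound 3 to compound 4 (0.06 log units; within the scatter) and a 1.1-fold lower number from compound 2 to compound 4 (0.06 log units; within the scatter). Among the compounds shown, an aromatic ring is therefore not required at this position, and the step away from butyl also holds for a six-membered non-aromatic ring: an at least 3.2-fold lower number from compound 1 to compound 4 (0.50 log units; beyond the scatter). Compound 1 stands only as a limit, so the full size of that step cannot be read: the limit of > 100000 nM in this assay, at which 1 of the 4 values shown sits.

From the compounds shown here alone, it remains open whether an open-chain amine such as diethylamino on the same carbonyl carbon would stay level with compound 4 or return toward the limit of compound 1. Going by these compounds, it is equally open whether cyclohexyl or unsubstituted phenyl would join the three ring-bearing compounds, which would show whether a ring of any kind is enough.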